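Trimming the ketone side chain of a glutamate receptor modulator

A few compounds are considered here, and "the series" means these few. Any claim that something is new, unique, unknown or untested is made for them only; others in the source may bear on it.

Compound 1: `COc1ccc(C(=O)O)cc1OCCCCOc1ccc(C(=O)CC(C)C)c(O)c1C`, 89.7%
Compound 2: `Cc1c(OCCCCOc2cccc(C(=O)O)c2)ccc(C(=O)CC(C)C)c1O`, 84.5%
Compound 3: `Cc1c(OCCCCOc2ccc(C(=O)O)cc2F)ccc(C(=O)CC(C)C)c1O`, 85%

Of the compounds shown here, three built on a shared core have been read out in an assay on HEK293 cells for positive allosteric modulation of metabotropic glutamate receptor 2 (Rattus norvegicus), read by thallium flux, with a stated time of 2.5 min; on this read-out lower numbers stand for smaller maximal responses and higher numbers for larger maximal responses. Compound 1 gives 89.7% in this assay and stands highest of the three numbers, but its steps to the others are both within the scatter: a number 5.2 percentage points lower from compound 1 to compound 2 (within the scatter), and compound 3 lies close to it as well. The step of a number 0.5 percentage points higher from compound 2 to compound 3 (within the scatter) is likewise within the scatter. Both measured steps sit on the carboxyphenyl end of the molecule.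

Compound 4, `COc1ccc(C(=O)O)cc1OCCCCOc1ccc(C(C)=O)c(O)c1C`, has not been measured in this assay. It differs from compound 1 at the other end of the core: hydrogen in place of isopropyl on a saturated chain carbon bound to a carbonyl carbon. Within the data shown here, no measured step touches the chain on the carbonyl carbon, so the two steps above tell nothing direct about this change; they only show that the three numbers so far sit close together. In the absence of a bearing step, the expectation for compound 4 is a value near compound 1, with no step beyond the scatter assumed, though the uncertainty is wider than for the measured steps. Compound 4 is therefore estimated at 84%, ranging from 60% to 100%, which means an expected step of a number 5.7 percentage points lower from compound 1 to compound 4 (within the scatter).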

Compound 4, largest response reached (reported as percent of maximum), in percent of the reference or control that the assay uses: 70.7%
For compound 4 the middle estimate is 13.3 percentage points above the measured one; measured number inside the range.
By their numbers in this assay, from the lowest: compound 4; then compounds 2, 3 and 1 (each within the scatter of the next).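

Replacing isopropyl with hydrogen on the saturated chain carbon bound to a carbonyl carbon, which shortens isobutylcarbonyl to acetyl, gives the only step beyond the scatter among those shown in this assay, with a number 19 percentage points lower from compound 1 to compound 4 (beyond the scatter) as its size. The chain on the carbonyl carbon is therefore a place where the largest response reached does respond to change, unlike the two steps at the carboxyphenyl end, which both stayed within the scatter. Even so, the response does not vanish with the acetyl group, since compound 4 still gives 70.7%, although no measurement at hand offers a reason for the lower number.

With only the isobutyl and methyl ends of this series shown, it remains open whether the response falls gradually or abruptly along intermediate chains such as ethyl or propyl, and whether a longer chain such as hexyl would match or exceed the value of compound 1. As far as these compounds go, it is also open whether the same change to acetyl would have a comparable effect with the 3-carboxyphenyl group of compound 2 or the 4-carboxy-2-fluorophenyl group of compound 3.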